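From isopropyl to ethylcarbamoyl on the ring nitrogen

A few compounds are considered here, and "the series" means these few. Any claim that something is new, unique, unknown or untested is made for them only; others in the source may bear on it.

In an in vitro ADME assay on microsomes from liver (Mus musculus) for pharmacokinetics, read by LC-MS, with a stated time of 10 min, tested at 1 uM (on this read-out higher numbers stand for fast clearance and lower numbers for slow clearance), compound 1 (`CN1C[C@H](C(=O)Nc2ccc(C(F)(F)F)cc2)[C@@H](c2ccc(/C=C/C(=O)Nc3ccccc3N)cc2)C1`) gives 23 mL/min/kg, compound 2 (`CN1C[C@H](C(=O)Nc2cccc(Cl)c2)[C@@H](c2ccc(/C=C/C(=O)Nc3ccccc3N)cc2)C1`) gives 58 mL/min/kg, and compound 3 (`CC(C)N1C[C@H](C(=O)Nc2ccc(Cl)cc2)[C@@H](c2ccc(/C=C/C(=O)Nc3ccccc3N)cc2)C1`) gives 38 mL/min/kg. Compound 3 thus lies within the scatter of both compound 1 and compound 2. Compound 4 (`CCNC(=O)N1C[C@H](C(=O)Nc2ccc(Cl)cc2)[C@@H](c2ccc(/C=C/C(=O)Nc3ccccc3N)cc2)C1`) carries ethylcarbamoyl in place of isopropyl on an amine nitrogen in a ring. For the measured compounds named here, the one measured step, a 2.5-fold higher number from compound 1 to compound 2 (0.40 log units; beyond the scatter), is modest and puts 3-chlorophenyl in place of 4-(trifluoromethyl)phenyl on an amide-type nitrogen, so it gauges size only roughly. Going by the values given here, no measured step touches the ring amine nitrogen, so no direction is supported and no shift beyond the scatter is expected. The estimated step is a 1.2-fold lower number from compound 3 to compound 4 (0.07 log units; within the scatter). For compound 4 the expected clearance is 32 mL/min/kg, with an estimated range of 14 mL/min/kg to 70 mL/min/kg.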

Compound 4, clearance: 25 mL/min/kg
Compound 4: middle estimate off by 1.3-fold (0.11 log units), on the high side; measured number inside the range.
By their numbers in this assay, from the lowest: compounds 1, 4, 3 and 2 (each within the scatter of the next, the first and the last beyond it).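

At this ring nitrogen, this assay gives its first measured step, a 1.5-fold lower number from compound 3 to compound 4 (0.18 log units; within the scatter), so ethylcarbamoyl stands in place of isopropyl with a shift that stays within the scatter. The change adds a hydrogen-bond donor and a hydrogen-bond acceptor to the group at this position, and the clearance result remains within that range. Nothing available explains this result. Open, going by these compounds, is how an acetyl group, a methylsulfonyl group or a longer alkyl chain on this nitrogen would compare. Also open, on these data alone, is whether ethylcarbamoyl would give a similar result with 4-(trifluoromethyl)phenyl on the amide nitrogen.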